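A few compounds are considered here, and "the series" means these few. Any claim that something is new, unique, unknown or untested is made for them only; others in the source may bear on it.

Compound 1 (`COc1ccc(OCCCON2C(N)=NC(N)=NC23CCOCC3)cc1`), compound 2 (`NC1=NC2(CCOCC2)N(OCCCOc2ccc(Cl)cc2)C(N)=N1`) and compound 3 (`Cc1ccc(OCCCON2C(N)=NC(N)=NC23CCOCC3)cc1`) share one core and differ in a single group on an aromatic carbon. In a functional assay on HL-60 cells (Homo sapiens) for antiproliferative activity, read by MTT assay, with a stated time of 72 h (a higher number here means a weaker inhibitor, a lower number a stronger inhibitor), compound 1 gives (1670 nM), compound 2 gives (330 nM) and compound 3 gives (2580 nM). Compound 3 sits level with compound 1 (a 1.5-fold higher number from compound 1 to compound 3 (0.19 log units; within the scatter)) and well apart from compound 2 (a 7.8-fold higher number from compound 2 to compound 3 (0.89 log units; beyond the scatter)). Compound 4 (`CC(C)(C)c1ccc(OCCCON2C(N)=NC(N)=NC23CCOCC3)cc1`) carries tert-butyl in place of methyl on that carbon (tert-butyl in place of methyl on an aromatic carbon). For the measured compounds named here, only chloro has clearly shifted the number here (a 5.1-fold lower number from compound 1 to compound 2 (0.70 log units; beyond the scatter)), and no measured compound has a group this large, so the forecast is loose. In this assay, a small expected move to a lower number stays within the scatter (a 1.7-fold lower number from compound 3 to compound 4 (0.24 log units; within the scatter)). The estimate for compound 4 is (1500 nM), with an expected range from (350 nM) to (5000 nM).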

Compound 4, half-maximal inhibitory concentration: 870 nM
Compound 4: the middle estimate sits 1.7-fold (0.24 log units) above what was measured; the measured number falls inside the stated range.
By their numbers in this assay, from the lowest: compound 2; then compounds 4, 1 and 3 (each within the scatter of the next, the first and the last beyond it).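

In this assay, the four-carbon tert-butyl group on this aromatic carbon gives a stronger result than methyl (a 3.0-fold lower number from compound 3 to compound 4 (0.47 log units; beyond the scatter)), so a larger group is tolerated here. It still falls short of chloro (a 2.6-fold higher number from compound 2 to compound 4 (0.42 log units; beyond the scatter)), while its difference from methoxy stays within the scatter (a 1.9-fold lower number from compound 1 to compound 4 (0.28 log units; within the scatter)), so the order does not simply follow group size. No supporting measurement explains these steps. As far as these compounds go, how an amine, a carboxylic acid or a longer chain would behave on this carbon remains open.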